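Removing the acetyl from the ring nitrogen of compound 2

A few compounds are considered here, and "the series" means these few. Any claim that something is new, unique, unknown or untested is made for them only; others in the source may bear on it.

Of the compounds shown here, two built on a shared core have been tested in a functional assay on the whole organism (strain Wistar) for inhibition, with Rattus norvegicus as the target, read by paw edema, with a stated time of 30 min, at a dose of 50 mg/kg by the oral route; a lower number here means less inhibition, a higher number more inhibition at the dose given (going by the name of the read-out). Compound 1 `Cc1ccc(C2=NNC(c3cn(-c4ccccc4)nc3-c3ccc(Cl)c(Cl)c3)C2)cc1` gives 38.3% in this assay, and compound 2 `CC(=O)N1N=C(c2ccc(F)cc2)CC1c1cn(-c2ccccc2)nc1-c1ccc(Cl)c(Cl)c1` gives 45.7%. The gap between these two numbers lies within the usual scatter of repeated measurements, so the figures show the two compounds performing alike rather than one ahead of the other.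

Compound 3 `Fc1ccc(C2=NNC(c3cn(-c4ccccc4)nc3-c3ccc(Cl)c(Cl)c3)C2)cc1` is not yet measured. It is made from compound 2 by a single change: hydrogen in place of acetyl on an amine nitrogen in a ring. The rest of the molecule stays as it is.

Among the compounds with values here, no pair of measured compounds differing in one place is available, so the size of this step in this assay is not known from data. Compound 1 also carries hydrogen on the ring nitrogen and gives 38.3%, which suggests the change leaves the read-out near where it is. The step from compound 2 to compound 3 is therefore expected to be small, a number 5.7 percentage points lower from compound 2 to compound 3 (within the scatter), not beyond the scatter. Compound 3 is estimated at 40%, in a range from 28% to 52%.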

Compound 3, a percentage reported as inhibition, in the whole organism at one dose (the size of the read-out at that dose, not a potency): 45.7%
Compound 3: the middle estimate sits 5.7 percentage points below what was measured; measured number inside the range.
By their numbers in this assay, from the lowest: compounds 1, 2 and 3 (each within the scatter of the next).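

In this assay, within the data shown here, the swap of acetyl for hydrogen on the amine nitrogen in a ring gives no change at the digits printed from compound 2 to compound 3 (within the scatter) and is the first direct reading of this position, showing that, for this pair, the read-out at this dose holds without the acetyl. The step of fluoro in place of methyl on an aromatic carbon gives a number 7.4 percentage points higher from compound 1 to compound 3 (within the scatter) and so also stays inside the usual spread of repeats. Nothing measured here gives a reason for either outcome.

From the compounds shown here alone, whether a benzoyl group or a longer acyl chain on the same nitrogen would leave the read-out just as unmoved remains open. So does the effect of a methoxy or a chloro group in place of the fluoro on the aromatic ring.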